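The source may hold more compounds than are shown below. What is called first, only, known or untested is meant among the compounds shown, and "the series" means these compounds.

Three compounds have been measured in a functional assay on the whole organism (strain albino) for inhibition, with Rattus norvegicus as the target, read by paw edema, with stated times of 1 h and 2 h, at a dose of 100 mg/kg by the oral route; on this read-out higher numbers stand for more inhibition at the one dose given (going by the name of the read-out) and lower numbers for less inhibition:

Compound 1 `N#Cc1c(-c2ccccc2)nc(SCC(=O)Nn2c(COc3ccc(Cl)cc3Cl)nc3ccccc3c2=O)[nH]c1=O` gives 86%.
Compound 2 `N#Cc1c(-c2ccc(O)cc2)nc(SCC(=O)Nn2c(COc3ccc(Cl)cc3Cl)nc3ccccc3c2=O)n(Cc2ccccc2)c1=O` gives 56.1%.
Compound 3 `N#Cc1c(Nc2ccccc2)nc(SCC(=O)Nn2c(COc3ccc(Cl)cc3Cl)nc3ccccc3c2=O)nc1-c1ccccc1` gives 78.1%.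

On these numbers compound 3 is the second highest of three. Its nearest neighbour is compound 1, whose number lies within the usual scatter of that of compound 3, so the two cannot be told apart. Compound 2 lies furthest away, its number being lower than that of compound 3 by more than the scatter. No two of the measured compounds differ in only one place, so none of these gaps can be tied to a single structural change.

Compound 4 `N#Cc1c(Nc2ccc(O)cc2)nc(SCC(=O)Nn2c(COc3ccc(Cl)cc3Cl)nc3ccccc3c2=O)nc1-c1ccccc1` has not been measured. It differs from compound 3 in one place: hydroxy in place of hydrogen on an aromatic carbon. The group enters on an aromatic carbon of a six-membered aromatic ring of carbon only, turning the anilino group into a (4-hydroxyphenyl)amino group. Among the measured compounds shown here, no measured pair isolates this change. Compound 2 also carries a hydroxy group, on a different ring and alongside other differences, and its value is the lowest shown, which gives only a weak hint of direction. In this assay a small step is expected, a number 6.1 percentage points lower from compound 3 to compound 4 (within the scatter), a decline that need not exceed the scatter. Compound 4 is expected to give about 72%, with a range from 55% to 88%.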

Compound 4, a percentage reported as inhibition, in the whole organism at one dose (the size of the read-out at that dose, not a potency): 59.7%
Beside the measured number, compound 4's estimate is 12.3 percentage points above it; low and high end bracket the measured number.
By their numbers in this assay, from the lowest: compounds 2 and 4 (each within the scatter of the next); then compounds 3 and 1 (each within the scatter of the next).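

Among the compounds shown here, this is the first measured pair that differs in one place only, so a single change can now be read on its own in this assay: putting hydroxy in place of hydrogen on the aromatic carbon of the anilino group gives a number 18.4 percentage points lower from compound 3 to compound 4 (beyond the scatter). At this position and at the one dose given, the change to a (4-hydroxyphenyl)amino group therefore lowers inhibition by more than the usual scatter. Nothing measured here explains the drop.

A single pair cannot show whether the loss belongs to the hydroxy group alone or would also appear with a methoxy group, a chlorine atom or an amine on the same carbon. It also leaves open whether hydroxy would have the same effect on the other phenyl group of the shared core.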